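Swapping benzyloxy for 4-(2-hydroxyethoxy)phenyl

The source may hold more compounds than are shown below. What is called first, only, known or untested is meant among the compounds shown, and "the series" means these compounds.

Measured so far in a functional assay on A549 cells (Homo sapiens) for inhibition, read by sulforhodamine B assay, with a stated time of 48 h (a higher number here means a weaker inhibitor, a lower number a stronger inhibitor), on the three compounds:
Compound 1 `COc1ccc(C(c2ccc(OC(C)CN(C)C)cc2)c2cccc3ccccc23)c(OC)c1OC` gives 11400 nM
Compound 2 `COc1ccc(C(O)(Cc2ccc(F)cc2)c2cccc3ccccc23)c(OC)c1OC` gives 5940 nM
Compound 3 `COc1ccc(C(OCc2ccccc2)c2cccc3ccccc23)c(OC)c1OC` gives 13500 nM

Compound 3, at 13500 nM in this assay, sits within the scatter of compound 1, while compound 2 shows a lower number, beyond the scatter of compound 3. The next compound is compound 4 `COc1ccc(C(c2ccc(OCCO)cc2)c2cccc3ccccc23)c(OC)c1OC`, which carries 4-(2-hydroxyethoxy)phenyl in place of benzyloxy on a saturated chain carbon bound to two aromatic carbons and has not yet been measured. Among the measured compounds shown here, no measured pair of compounds differs in one place, so the data offer no direct guide to this change. Compound 1, at 11400 nM with a substituted phenyl on that same carbon, is the closest reference, so no step beyond the scatter is expected in this assay and any small shift should lean towards a lower number. The expected change is a 1.4-fold lower number from compound 3 to compound 4 (0.13 log units; within the scatter) and would lie within the scatter. For compound 4 the estimated value is 10000 nM with an expected range from 4000 nM to 22000 nM in this test.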

Compound 4, half-maximal inhibitory concentration: > 20000 nM
Compound 4 gave a limit, no number; the forecaster's own chance of this, stated with the estimate: 15%; middle value at least 2.0-fold (0.30 log units) from the limit.
By their numbers in this assay, from the lowest: compounds 2, 1 and 3 (each within the scatter of the next, the first and the last beyond it). At a limit, above all of these: compound 4.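

In this assay, compound 4 gives a limit and not a number: the limit of > 20000 nM in this assay, at which 1 of the 4 values shown sits.

Among the compounds shown here, this adds the first one-place steps: an at least 1.4-fold higher number from compound 3 to compound 4 (0.17 log units; that floor lies within the scatter) for 4-(2-hydroxyethoxy)phenyl in place of benzyloxy on a saturated chain carbon bound to two aromatic carbons, and an at least 1.7-fold higher number from compound 1 to compound 4 (0.24 log units; that floor lies within the scatter) for 2-hydroxyethyl in place of 1-((dimethylamino)methyl)ethyl on an oxygen on an aromatic ring. Both are floors that lie within the scatter, yet neither points towards a lower number, so neither change brought a gain in this assay.

From the compounds shown here alone, how far compound 4 lies past its limit stays open, so the true size of both steps is unknown. Also open, going by these compounds, is whether a carboxylic acid or a longer chain ending in a morpholine on that oxygen would give a lower number.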